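The compounds below may be only part of what the source reports. "The series", "measured", "known", "first", "only" and "open" are said of these compounds alone.

Among the three compounds measured in a functional assay on CCRF-CEM cells (Homo sapiens) for cytotoxicity, with a stated time of 72 h (a lower number here means a stronger inhibitor, a higher number a weaker inhibitor), compound 1, `COc1cc(/C=C2\CCC/C(=C\c3ccccc3[N+](=O)[O-])C2=O)cc(OC)c1OC`, stands lowest and is thus the strongest inhibitor, giving 402 nM. Compound 2, `O=C1/C(=C/c2ccc(F)cc2)CCC/C1=C\c1ccccc1[N+](=O)[O-]`, gives 1510 nM, and compound 3, `O=C1/C(=C/c2ccc(Cl)cc2)CCC/C1=C\c1cccc([N+](=O)[O-])c1`, gives 1750 nM; both sit beyond the scatter from compound 1. Compound 4, `COc1cc(/C=C2\CCC/C(=C\c3ccc([N+](=O)[O-])cc3)C2=O)cc(OC)c1OC`, differs from compound 1 in one way: 4-nitrophenyl in place of 2-nitrophenyl on a double-bonded chain carbon bound to a double-bonded ring carbon. For the measured compounds named here, no pair of measured compounds isolates this change, so its effect in this assay is unknown here; the nitro group moves within the same ring and nothing else changes. The step from compound 1 to compound 4 is expected to be small, within the scatter, so the estimated 1.0-fold higher number from compound 1 to compound 4 (0.02 log units; within the scatter) carries little direction. Compound 4 is therefore expected to give about 420 nM in this assay, in a range from 200 nM to 900 nM.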

Compound 4, half-maximal inhibitory concentration: 4610 nM
The estimate for compound 4 lay 11-fold (1.04 log units) below the measured number; the whole stated range lies below it.
By their numbers in this assay, from the lowest: compound 1; then compounds 2 and 3 (each within the scatter of the next); then compound 4.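

Moving the nitro group within the same ring is far from a silent change in this assay: 4-nitrophenyl in place of 2-nitrophenyl gives an 11-fold higher number from compound 1 to compound 4 (1.06 log units; beyond the scatter) even though both compounds hold the same atoms. For the compounds shown here, at this place, where the nitro group sits on the ring matters greatly, which the earlier compounds, differing in more than one place, could not show. Nothing measured here explains the size of this step.

From the compounds shown here alone, whether an amine or a carboxylic acid in place of the nitro group would keep the number close to that of compound 1 remains open. So does whether the same move would have as large an effect with a different group on the other side of the core.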